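Aryl swap on the shared core: compound 3 to compound 4

This account rests on a few compounds, and the source may have more. Where it says the series, first, only, none or still open, it means among the compounds named here.

- compound 1 `CCOc1ccc(-c2cc(=O)c3c(o2)C(CC)(CC)C(=O)C(CC)=C3O)cc1`: > 52.4 uM
- compound 2 `CCC1=C(O)c2c(oc(-c3cccc(OC)c3)cc2=O)C(CC)(CC)C1=O`: 13.3 uM
- compound 3 `CCC1=C(O)c2c(oc(-c3ccccc3F)cc2=O)C(CC)(CC)C1=O`: > 56.2 uM

All three were read in a functional assay on KB cells (Homo sapiens) for antiproliferative activity, read by sulforhodamine B assay, with a stated time of 3 days; on this read-out higher numbers stand for an effect only at larger amounts of compound and lower numbers for an effect already at smaller amounts. Compound 1 gives > 52.4 uM, which is a limit. Compound 3 gives > 56.2 uM, also a limit, so compound 3 has no measured number of its own. Only compound 2 has a number, 13.3 uM.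

Compound 4 `CCC1=C(O)c2c(oc(-c3cc(C)c(C)cc3C)cc2=O)C(CC)(CC)C1=O` carries 2,4,5-trimethylphenyl in place of 2-fluorophenyl on an aromatic carbon, next to the ring oxygen: 2,4,5-trimethylphenyl in place of 2-fluorophenyl on an aromatic carbon.

The measured steps all change the aryl group at this same place. The closest guide is an at least 4.2-fold higher number from compound 2 to compound 3 (0.62 log units; beyond the scatter), which lies beyond the scatter, as does an at least 3.9-fold lower number from compound 1 to compound 2 (0.59 log units; beyond the scatter). The remaining step, a step that the two limits leave unreadable from compound 1 to compound 3, gives no size. None of these compounds carries the trimethylphenyl group, so the direction is an expectation only. The size of an at least 4.2-fold higher number from compound 2 to compound 3 (0.62 log units; beyond the scatter) sets the scale, and a modest move toward lower numbers is expected, with a further limit quite possible. The expected change in this assay is an at least 2.2-fold lower number from compound 3 to compound 4 (0.35 log units; beyond the scatter). Compound 4 is estimated at 25 uM, with an expected range of 8 uM to 60 uM.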

Compound 4, concentration for half-maximal effect: 8.2 uM
Compound 4: middle estimate off by 3.0-fold (0.48 log units), on the high side; measured number inside the range.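

In this assay, this place on an aromatic carbon next to the ring oxygen now has a second aryl group with a measured number: with a 1.6-fold lower number from compound 2 to compound 4 (0.21 log units; within the scatter), 2,4,5-trimethylphenyl and 3-methoxyphenyl stand level, so an oxygen on the aryl group is not needed for a number in this region among these compounds. The trimethylphenyl group also separates clearly from the two aryl groups that gave only limits, with an at least 6.8-fold lower number from compound 3 to compound 4 (0.83 log units; beyond the scatter) and an at least 6.3-fold lower number from compound 1 to compound 4 (0.80 log units; beyond the scatter), so the aryl group at this place can move the read-out beyond the scatter in either direction. Compound 3 stands only at a limit, as does compound 1, so these two steps give a bound and not a size: the limit of > 56.2 uM in this assay, at which 1 of the 4 values shown sits.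

Still open, as far as these compounds go, is which of the three methyl groups of 2,4,5-trimethylphenyl matters, and whether a single methyl group at any of those places would read the same. Also open, from the compounds shown here alone, is how an aryl group carrying an amine or a carboxylic acid would read in this assay, and whether anything on the shared core away from this place changes the picture.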